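A few compounds are considered here, and "the series" means these few. Any claim that something is new, unique, unknown or untested is made for them only; others in the source may bear on it.

Working notes, series in a functional assay on HepG2 cells (Homo sapiens) for antiproliferative activity, read by MTT assay, with a stated time of 48 h; a higher number here means a weaker inhibitor, a lower number a stronger inhibitor:

- compound 1 `O=c1cc(-c2ccccc2)oc2cc(OCc3ccccc3)c(OCCCN3CCCCC3)c(O)c12`: 2200 nM
- compound 2 `O=c1cc(-c2ccccc2)oc2cc(OCc3ccccc3)c(OCCCN3CCCC3)c(O)c12`: 4200 nM
- compound 3 `O=c1cc(-c2ccccc2)oc2cc(O)c(OCCCCN3CCCC3)c(O)c12`: > 100000 nM, a limit and not a number

Compound 3 has no number, only a limit: the limit of > 100000 nM in this assay, at which 1 of the 3 values shown sits.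

Next is compound 4 `O=c1cc(-c2ccccc2)oc2cc(OCc3ccccc3)c(OCCCCN3CCCC3)c(O)c12`, which is compound 3 with one change: benzyl in place of hydrogen on an oxygen on an aromatic ring. This is hydroxy to benzyloxy.

Going by the values given here, no measured step covers this change directly. Among the compounds with values here, the only measured step, a 1.9-fold higher number from compound 1 to compound 2 (0.28 log units; within the scatter), exchanges piperidin-1-yl for pyrrolidin-1-yl, so it suggests little sensitivity to that group but does not address the hydroxy. The better guide is that benzyloxy is present in both measured numeric members, as it will be in compound 4. Of these, compound 1 gives 2200 nM and compound 2 gives 4200 nM.

A large move to a lower number, meaning a stronger inhibitor, is therefore expected, with an estimated size of an at least 28-fold lower number from compound 3 to compound 4 (1.45 log units; beyond the scatter). For compound 4 the estimated value is 3500 nM, with an expected range of 1000 nM to 15000 nM.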

Compound 4, half-maximal inhibitory concentration: 2000 nM
For compound 4 the middle estimate is 1.8-fold (0.24 log units) above the measured one, within the range that was stated.
By their numbers in this assay, from the lowest: compounds 4, 1 and 2 (each within the scatter of the next, the first and the last beyond it). At a limit, above all of these: compound 3.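

In this assay, the oxygen on an aromatic ring proves to be the most sensitive place shown so far, with benzyl in place of hydrogen giving an at least 50-fold lower number from compound 3 to compound 4 (1.69 log units; beyond the scatter) on the hydroxy to benzyloxy change. Compound 3 has only a limit and not a number: the limit of > 100000 nM in this assay, at which 1 of the 4 values shown sits. With benzyloxy kept, the chain and amine changes matter far less, giving a 2.1-fold lower number from compound 2 to compound 4 (0.32 log units; beyond the scatter) as a modest step and a 1.1-fold lower number from compound 1 to compound 4 (0.04 log units; within the scatter) as a step within the scatter.

Still open, from the compounds shown here alone, is whether methyl or a substituted benzyl on that oxygen would serve as benzyl does. Also open, going by these compounds, is how a longer chain, or morpholin-4-yl or dimethylamino in place of the ring amines, would read with benzyloxy kept.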